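A few compounds are considered here, and "the series" means these few. Any claim that something is new, unique, unknown or untested is made for them only; others in the source may bear on it.

Three compounds share one core and differ only in the amine carried on a saturated chain carbon bound to an aromatic carbon. In an assay on nucleic acid for inhibition of Nucleic Acid, read by fluorescence, tested at 100 uM (on this read-out lower numbers stand for less inhibition and higher numbers for more inhibition at the one concentration tested (going by the name of the read-out)), compound 1 `CN(CCCc1ccccc1)Cc1cn(C2CCCCC2OC(=O)COc2ccccc2)nn1` gives 42%, compound 2 `CN(Cc1cn(C2CCCCC2OC(=O)COc2ccccc2)nn1)CC1CCCCC1` gives 37%, and compound 3 `CCCCN(CCCC)Cc1cn(C2CCCCC2OC(=O)COc2ccccc2)nn1` gives 26%. Compound 3 stands lowest of the three: the nearest is compound 2, the step of a number 11 percentage points lower from compound 2 to compound 3 (beyond the scatter) being beyond the scatter, and the furthest is compound 1, with a number 16 percentage points lower from compound 1 to compound 3 (beyond the scatter). The step of a number 5 percentage points lower from compound 1 to compound 2 (within the scatter) lies within the scatter.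

Compound 4 `CC(C)CCN(C)Cc1cn(C2CCCCC2OC(=O)COc2ccccc2)nn1` is not yet measured. The change from compound 3 is isopentyl(methyl)amino in place of dibutylamino on a saturated chain carbon bound to an aromatic carbon. Both steps that bear on it, from compound 1 and from compound 2 to compound 3, replaced a methyl-bearing amine with dibutylamino and moved the number down modestly. Compound 4 returns a methyl to the amine while shortening the other chain, so a modest rise back toward compound 2 in this assay is expected, as a number 9 percentage points higher from compound 3 to compound 4 (within the scatter). Compound 4 is therefore estimated at 35% in this assay, with a range from 24% to 46%.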

Compound 4, a percentage reported as inhibition, at one concentration (the size of the read-out at that concentration, not a potency): 59%
Compound 4: the middle estimate sits 24 percentage points below what was measured, and the stated range ends below it.
By their numbers in this assay, from the lowest: compound 3; then compounds 2 and 1 (each within the scatter of the next); then compound 4.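

In this assay, this position proves able to carry a number well above all three earlier compounds, with a number 33 percentage points higher from compound 3 to compound 4 (beyond the scatter), a number 22 percentage points higher from compound 2 to compound 4 (beyond the scatter) and a number 17 percentage points higher from compound 1 to compound 4 (beyond the scatter), so the amine here matters more than the earlier spread suggested. The earlier compounds shown here alone could be read as linking a ring in the amine to a higher number, since compounds 1 and 2 each stand above the ring-free compound 3, but compound 4 goes against that reading: its isopentyl(methyl)amino has no ring, as with dibutylamino, yet it stands above both ring-bearing compounds. Nothing available here accounts for the size of this rise.

The change from dibutylamino alters both arms of the amine at once, leaving open whether the rise follows the methyl, the branch in the isopentyl chain, or the two together; methyl(pentyl)amino, with an unbranched chain, and diisopentylamino, with no methyl, would pull these apart. Also open, from the compounds shown here alone, is how far the trend extends to smaller amines such as dimethylamino, and whether the reading at a single concentration would hold across a range of concentrations.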